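Removing the hydroxycyclohexylamino arm from compound 3

The source may report more compounds than this note shows. Statements on the series, on what has been measured and on what is new or still open speak of the compounds shown alone.

Compound 3 `O[C@H]1CC[C@H](NCCCOc2ccc([C@H]3CC[C@]4(CC3)OOC3(O4)C4CC5CC(C4)CC3C5)cc2)CC1` carries the shared core with a 3-((4-hydroxycyclohexyl)amino)propyl group on the aromatic oxygen. In a physicochemical assay for solubility, read by nephelometry, measured as kinetic solubility, with a stated time of 30 min (a lower number here means a less soluble compound, a higher number a more soluble compound), compound 3 gives only a limit, > 100 ug/mL (the limit of > 100 ug/mL in this assay, at which 1 of the 3 values shown sits). Compound 1 `N[C@H]1CC[C@@H](Oc2ccc([C@H]3CC[C@]4(CC3)OOC3(O4)C4CC5CC(C4)CC3C5)cc2)CC1` gives 25 ug/mL and compound 2 `c1cc([C@H]2CC[C@]3(CC2)OOC2(O3)C3CC4CC(C3)CC2C4)ccc1OCC1CCNCC1` gives 12.5 ug/mL in this assay; the steps of an at least 4.0-fold higher number from compound 1 to compound 3 (0.60 log units; beyond the scatter) and an at least 8.0-fold higher number from compound 2 to compound 3 (0.90 log units; beyond the scatter) both rise when the longer amino chain enters. Compound 4 `CC(C)(N)CCOc1ccc([C@H]2CC[C@]3(CC2)OOC2(O3)C3CC4CC(C3)CC2C4)cc1` differs from compound 3 by 1-amino-1-methylethyl in place of ((4-hydroxycyclohexyl)amino)methyl on a saturated chain carbon, two bonds along the chain from an oxygen on an aromatic ring, which removes that arm again and leaves a shorter primary amine. Because the steps of an at least 4.0-fold higher number from compound 1 to compound 3 (0.60 log units; beyond the scatter) and an at least 8.0-fold higher number from compound 2 to compound 3 (0.90 log units; beyond the scatter) were at least modest, a fall is expected for compound 4, though its size is uncertain since compound 3 sits at a limit. Compound 4 is therefore estimated at 30 ug/mL, between 10 ug/mL and 100 ug/mL, a step of an at least 3.3-fold lower number from compound 3 to compound 4 (0.52 log units; beyond the scatter).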

Compound 4, solubility: 50 ug/mL
Compound 4: the middle estimate sits 1.7-fold (0.22 log units) below what was measured, within the range that was stated.
By their numbers in this assay, from the lowest: compounds 2, 1 and 4 (each within the scatter of the next, the first and the last beyond it). At a limit, above all of these: compound 3.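

With 1-amino-1-methylethyl at this place on the chain, this assay shows a group with no ring giving a 4.0-fold higher number from compound 2 to compound 4 (0.60 log units; beyond the scatter), alongside a 2.0-fold higher number from compound 1 to compound 4 (0.30 log units; within the scatter). Taking away the ((4-hydroxycyclohexyl)amino)methyl arm gives an at least 2.0-fold lower number from compound 3 to compound 4 (0.30 log units; that floor lies within the scatter), which is a floor only. The true size of that step stays open because the value of compound 3 is a limit: the limit of > 100 ug/mL in this assay, at which 1 of the 4 values shown sits.

Left open is whether a plain cyclohexylamino group without the hydroxyl would read nearer compound 3 or compound 4. Also open, as far as these compounds go, is how a carboxylic acid at this place would read.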